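Removing a Chloro Group from a Dichlorinated Purine Core

The source may report more compounds than this note shows. Statements on the series, on what has been measured and on what is new or still open speak of the compounds shown alone.

Measured compounds:
compound 1, `ClCc1cccc(Cn2cnc3nc(Cl)nc(Cl)c32)c1`: "not determined" (no result reported)
compound 2, `ClCc1ccccc1Cn1cnc2ncnc(Cl)c21`: 7070 nM

Compound 1 carries two chloro groups on its core; in a functional assay on LOX IMVI cells (Homo sapiens) for cytotoxicity, read by sulforhodamine B assay, with a stated time of 48 h (on this read-out higher numbers stand for lower toxicity in this test and lower numbers for higher toxicity in this test), compound 1 gives "not determined" (no result reported), so no number stands beside it. For the measured compounds named here, compound 2, `ClCc1ccccc1Cn1cnc2ncnc(Cl)c21`, has only one chloro group on the core and a chloromethyl group placed differently on the benzyl ring; in this assay compound 2 gives 7070 nM. Compound 1 therefore stands nowhere on the numbers shown, and no comparison between compound 1 and compound 2 is possible.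

Compound 3, `ClCc1cccc(Cn2cnc3ncnc(Cl)c32)c1`, differs from compound 1 as follows: hydrogen in place of chloro on an aromatic carbon. Going by the values given here, with no value for compound 1, no step can be calculated, and its size in this assay cannot be expected in any direction from the data themselves. Among the compounds with values here, the only foothold is compound 2, which shares the single-chloro core with compound 3 and differs from it only in where the chloromethyl group sits. Compound 3 is expected to give about 7000 nM, within a range of 2500 nM to 20000 nM.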

Compound 3, concentration lethal to 50% of the cells: 43700 nM
Estimate against measurement, compound 3: 6.2-fold (0.80 log units) below; measured number outside the range, above it.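

For the compounds shown here, with no single number for compound 1 in this assay, no step from compound 1 to compound 3 can be read. The compounds shown leave open how replacing that chloro group with hydrogen changes the result in this assay. No supporting evidence bears on the value of compound 3.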